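From compound 1 to compound 3: one ether group changes

A few compounds are considered here, and "the series" means these few. Any claim that something is new, unique, unknown or untested is made for them only; others in the source may bear on it.

Compound 1 `CC(C)(C)c1ccc(Oc2ccc3c(NCCCNCc4ccco4)ccnc3c2)cc1` was tested in an ADME assay on HepG2 cells (Homo sapiens) for cytotoxicity, read by luminescence, CellTiter-Glo and ATP content, with a stated time of 72 h (on this read-out higher numbers stand for an effect only at larger amounts of compound and lower numbers for an effect already at smaller amounts), where compound 1 gives 3100 nM. Compound 2 `COc1cccc(CNCCCNc2ccnc3cc(CCC(C)C)ccc23)c1O` gives 5390 nM in this assay; the two numbers lie within the usual scatter of each other, so neither compound stands apart from the other. Compound 3 `COc1ccccc1Oc1ccc2c(NCCCNCc3ccco3)ccnc2c1` keeps the shared core of compound 1 and differs from it only by 2-methoxyphenyl in place of 4-(tert-butyl)phenyl on an oxygen on an aromatic ring. For the measured compounds named here, no measured pair shows what such a swap does here, so the step is expected to stay small, in neither direction beyond the scatter. For compound 3 the value is expected near 3500 nM, with a range from 1200 nM to 10000 nM. The expected step is a 1.1-fold higher number from compound 1 to compound 3 (0.05 log units; within the scatter), no larger than the scatter.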

Compound 3, half-maximal effective concentration: 6500 nM
For compound 3 the middle estimate is 1.9-fold (0.27 log units) below the measured one, within the range that was stated.
By their numbers in this assay, from the lowest: compounds 1, 2 and 3 (each within the scatter of the next, the first and the last beyond it).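

In this assay, for the compounds shown here, putting 2-methoxyphenyl in place of 4-(tert-butyl)phenyl on an oxygen on an aromatic ring gives a 2.1-fold higher number from compound 1 to compound 3 (0.32 log units; beyond the scatter) and provides the first comparison here of compounds differing in one place. The group at this position can therefore shift the read-out, though only modestly. No measurement shown gives a reason for this step. The swap changes both the size of the group and its oxygen count, and this single pair cannot separate the two. A plain phenyl group on the same oxygen would be one further comparison.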